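From Carboxylic Acid to Isobutyl Amide: An Expected Step

The source may hold more compounds than are shown below. What is called first, only, known or untested is meant among the compounds shown, and "the series" means these compounds.

compound 1 `CCCSc1nc(Cl)c2c(n1)N(Cc1ccccc1)C(C(=O)O)N2`: > 64000 nM
compound 2 `CCCSc1nc(Cl)c2c(n1)N(Cc1cccs1)C(C(=O)N1CCN(C)CC1)N2`: 39400 nM

In a functional assay on TE-1 cells (Homo sapiens) for antiproliferative activity, read by MTT assay, with a stated time of 72 h (on this read-out higher numbers stand for weaker inhibition and lower numbers for stronger inhibition), compound 1 gives > 64000 nM, which is a limit of the assay and not a number (the limit of > 64000 nM in this assay, at which 1 of the 2 values shown sits). Compound 2 `CCCSc1nc(Cl)c2c(n1)N(Cc1cccs1)C(C(=O)N1CCN(C)CC1)N2` carries a thienylmethyl group and a methylpiperazine amide where compound 1 carries a benzyl group and a carboxylic acid. In this assay compound 2 gives 39400 nM. No single step between these two is shown, so only what their values show can be said: compound 2 has a measured number where compound 1 has a limit.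

Compound 3 `CCCSc1nc(Cl)c2c(n1)N(Cc1ccccc1)C(C(=O)NCC(C)C)N2` differs from compound 1 in one place: isobutylamino in place of hydroxy on a carbonyl carbon. Since compound 1 sits at the limit, the step from compound 1 to compound 3 is expected to run toward stronger inhibition, with an expected size of an at least 2.1-fold lower number from compound 1 to compound 3 (0.32 log units; beyond the scatter). Compound 3 is therefore expected to give about 30000 nM in this assay, within a range from 8000 nM to 100000 nM.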

Compound 3, half-maximal inhibitory concentration: 46600 nM
The estimate for compound 3 lay 1.6-fold (0.19 log units) below the measured number, and the stated range covers the measured number.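

At this carbonyl carbon, with the benzyl group kept in place, the change from hydroxy to isobutylamino turns a limit into a measured number in this assay. The change gives an at least 1.3-fold lower number from compound 1 to compound 3 (0.13 log units; that floor lies within the scatter), so its true size remains unfixed: it could be larger, or it could be no larger than the scatter. The value of compound 1 is a limit of the assay and not a number, so the step can be read only as a floor: the limit of > 64000 nM in this assay, at which 1 of the 3 values shown sits.

From the compounds shown here alone, it remains open whether a primary amine, a longer alkyl chain or a cyclopropylamino group at this carbonyl carbon would move the number further. Compound 2 differs from compound 3 in two places, so that pair cannot separate the effect of the thienylmethyl group from that of the methylpiperazine amide.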